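The compounds below may be only part of what the source reports. "The series", "measured", "known", "first", "only" and "open" are said of these compounds alone.

Measured so far in a functional assay on the whole organism (strain Kunming) with Mus musculus as the target, in the maximal electroshock model; a lower number here means that less compound is needed, a higher number that more compound is needed for the effect:

Compound 1 `O=C(/C=C/c1ccc(F)cc1)NCCO`: 45.6 mg/kg
Compound 2 `O=C(/C=C/c1ccc(Cl)cc1)NCCO`: 73.4 mg/kg

Going by the values given here, only two compounds have been measured, and their values lie within the usual scatter of each other, so compound 2 cannot be separated from compound 1. Compound 3 `O=C(/C=C/c1ccc(Br)cc1)NCCO` is still to be measured in this assay. It differs from compound 2 by bromo in place of chloro on an aromatic carbon.

Among the compounds with values here, one measured step bears on this change, a swap of one halogen for another at the same place, chloro in place of fluoro. That step is a 1.6-fold higher number from compound 1 to compound 2 (0.21 log units; within the scatter). With this single small step as the guide, no change beyond the scatter is expected, and no direction can be called. The expected step is a 1.0-fold lower number from compound 2 to compound 3 (0.02 log units; within the scatter). For compound 3 the estimated value is 70 mg/kg, with an expected range from 35 mg/kg to 140 mg/kg.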

Compound 3, dose for half-maximal effect: 76 mg/kg
Compound 3: the middle estimate sits 1.1-fold (0.04 log units) below what was measured; measured number inside the range.
By their numbers in this assay, from the lowest: compounds 1, 2 and 3 (each within the scatter of the next).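

In this assay, bromo in place of chloro on an aromatic carbon gives a 1.0-fold higher number from compound 2 to compound 3 (0.02 log units; within the scatter), and bromo in place of fluoro gives a 1.7-fold higher number from compound 1 to compound 3 (0.22 log units; within the scatter). Going by these compounds alone, the earlier compounds offered only one halogen swap, whereas all three pairs among fluoro, chloro and bromo at this position now lie within the scatter, so no order among compound 1, compound 2 and compound 3 can be stated. Nothing measured here accounts for this result.

The compounds shown leave open whether a group other than a halogen at this position, such as methoxy, a nitrile or an amine, would give a step beyond the scatter. They also leave open what a longer chain or a carboxylic acid in place of the hydroxyl-bearing chain on the amide would do.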